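Iodo in Place of Methyl on the Urea of Compound 1

This account rests on a few compounds, and the source may have more. Where it says the series, first, only, none or still open, it means among the compounds named here.

Compound 1 `Cc1ccccc1NC(=O)N[C@H](C)c1ccccc1` was tested in an ADME assay on the whole organism with Oryza sativa as the target, tested at 10 uM (a lower number here means a stronger effect, a higher number a weaker effect of the compound at the concentration tested), where compound 1 gives 99%. Its mirror image, compound 2 `Cc1ccccc1NC(=O)N[C@@H](C)c1ccccc1`, gives 99% in the same measurement, and the step of no change at the digits printed from compound 1 to compound 2 (within the scatter) shows no change at the digits printed, which accords with the fact that (the fact that compounds 1 and 2 differ only in the configuration as drawn). Compound 3 `CCOC(=O)c1ccc(NC(=O)N[C@H](C)c2ccccc2)cc1`, carrying an ethyl ester on the aryl ring, gives 92%. Compound 1 therefore stands level with compound 2, the two together the highest of the three numbers, while compound 3 sits within the scatter of compound 1.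

Compound 4 `C[C@@H](NC(=O)Nc1ccccc1I)c1ccccc1` differs from compound 1 by iodo in place of methyl on an aromatic carbon. Within the data shown here, the only measured step that starts from compound 1 is the one to compound 2, and it concerns configuration alone, so no measured step exchanges a group at this place. All three measured values lie within the scatter of one another, and nothing among them points to a change of more than the usual spread when a single group on the aryl ring is replaced. The step of a number 3 percentage points lower from compound 1 to compound 4 (within the scatter) is therefore expected to stay within the scatter. Compound 4 is estimated to give 96%, with a range from 85% to 100%.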

Compound 4, a percentage reported as activity, at one concentration (the size of the read-out at that concentration, not a potency): 96%
Compound 4: middle estimate and measured number agree at the digits printed; low and high end bracket the measured number.
By their numbers in this assay, from the lowest: compounds 3, 4, 1 and 2 (each within the scatter of the next).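

In this assay, among these compounds, the exchange of methyl for iodo on an aromatic carbon, ortho to a large group, gives the first measured step that replaces a group at this place, and it reads a number 3 percentage points lower from compound 1 to compound 4 (within the scatter). The earlier step concerned configuration alone, whereas this one shows that a group on the six-membered aromatic ring can be changed, here one heavy atom for another with no change in hydrogen-bond donors, acceptors or charge, without the read-out leaving the scatter. No measured property of methyl or iodo is at hand that would bear on this step.

On these data alone, a single exchange with a result within the scatter does not show whether this place matters at all for the read-out, and it remains open whether an amine, a carboxylic acid or a longer chain on this aromatic carbon would move the number beyond the scatter. Also open, as far as these compounds go, is whether the mirror image of compound 4 would match compound 4 in the way compound 2 matches compound 1.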